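From dimethylamino to allyl(methyl)amino in compound 4

This account rests on a few compounds, and the source may have more. Where it says the series, first, only, none or still open, it means among the compounds named here.

Values in an ADME assay on PBMC cells (Homo sapiens) for cytotoxicity, with a stated time of 5 days (a lower number here means a stronger inhibitor, a higher number a weaker inhibitor), for the measured compounds
- Compound 1 `CN(C)c1nc(N)nc2c1ncn2[C@H]1C[C@H](N=[N+]=[N-])[C@@H](CO)O1` gives > 100000 nM
- Compound 2 `COc1nc(F)nc2c1ncn2[C@H]1C[C@H](N=[N+]=[N-])[C@@H](CO)O1` gives 9400 nM
- Compound 3 `CN(C)c1nc(Cl)nc2c1ncn2[C@H]1C[C@H](N=[N+]=[N-])[C@@H](CO)O1` gives > 100000 nM

Compound 1 has the entry > 100000 nM and this is a limit and not a number. Compound 3 has the entry > 100000 nM and this is likewise a limit. Only compound 2 reads as a number (9400 nM). Compound 1 thus stands at the limit of > 100000 nM in this assay, at which 2 of the 3 values shown sit, and offers no number to count from.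

Compound 4 `C=CCN(C)c1nc(N)nc2c1ncn2[C@H]1C[C@H](N=[N+]=[N-])[C@@H](CO)O1` differs from compound 1 by vinyl in place of hydrogen on a saturated chain carbon bound to a nitrogen on an aromatic ring with vinyl in place of hydrogen on a saturated chain carbon bound to a nitrogen on an aromatic ring, so dimethylamino becomes allyl(methyl)amino. Going by the values given here, the only measured step is a step that the two limits leave unreadable from compound 1 to compound 3 and it concerns a different change, so it gives no size to carry over. No step beyond the scatter is therefore expected in this assay on this evidence. The estimated step is a number no higher from compound 1 to compound 4 (the limit leaves the size open) and it is an expectation only. Compound 4 is expected at 100000 nM within an estimated range (30000 nM to 300000 nM).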

Compound 4, half-maximal inhibitory concentration: > 100000 nM
Compound 4 ended at the assay's limit; the forecaster's own chance of this, stated with the estimate: 65%; the middle value sits exactly at the limit.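

In this assay compound 4 gives > 100000 nM as a limit and not a number. Compound 1 gives > 100000 nM as a limit too, so no step can be read between compound 1 and compound 4. The compounds shown leave open whether allyl(methyl)amino and dimethylamino differ at all in this read-out.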